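A Trifluoromethyl Swap on the Sulfonamide Nitrogen

This account rests on a few compounds, and the source may have more. Where it says the series, first, only, none or still open, it means among the compounds named here.

Compound 1 `O=C(/C=C/c1cccnc1)NCCCCCc1cccc(S(=O)(=O)Nc2ccccc2)c1` gives 16.5 nM in an assay on isolated protein for inhibition of Nicotinamide phosphoribosyltransferase (Homo sapiens), read by WST assay, with stated times of 60 min, 5 min and 30 min, in the presence of a further agent that is not named here; a lower number here means a stronger inhibitor, a higher number a weaker inhibitor.
Compound 2 `Cc1ccccc1NS(=O)(=O)c1cccc(CCCCCCNC(=O)/C=C/c2cccnc2)c1` gives 5.08 nM in this assay.

Of these two numbers, compound 2 has the lower one; compound 1 lies above it by a gap beyond the usual scatter. Compound 3 `O=C(/C=C/c1cccnc1)NCCCCCCc1cccc(S(=O)(=O)Nc2ccc(C(F)(F)F)cc2)c1` is built from compound 2 by one change: 4-(trifluoromethyl)phenyl in place of 2-methylphenyl on a sulfonamide nitrogen. Going by the values given here, no measured pair shows this change, so nothing here tells its effect directly. A modest step, leaning towards a weaker inhibitor, is expected, a 1.8-fold higher number from compound 2 to compound 3 (0.25 log units; within the scatter). Compound 3 is estimated at 9 nM in this assay, within a range from 2.5 nM to 30 nM.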

Compound 3, half-maximal inhibitory concentration: 24.5 nM
For compound 3 the middle estimate is 2.7-fold (0.43 log units) below the measured one; low and high end bracket the measured number.
By their numbers in this assay, from the lowest: compound 2; then compounds 1 and 3 (each within the scatter of the next).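

Putting 4-(trifluoromethyl)phenyl in place of 2-methylphenyl on the sulfonamide nitrogen gives a 4.8-fold higher number from compound 2 to compound 3 (0.68 log units; beyond the scatter) in this assay and so a weaker inhibitor. Going by these compounds alone, this is the first direct reading of a change at this position, and it shows that the group on that nitrogen affects the result. Nothing available here explains the loss.

This single swap alters both the substituent and where it sits on the ring, and the compounds shown do not separate the two. Going by these compounds, how 4-methylphenyl, 2-(trifluoromethyl)phenyl or a phenyl carrying an amine would compare remains open.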